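From 3,4-difluorophenyl to propylamino on a carbonyl carbon

This account rests on a few compounds, and the source may have more. Where it says the series, first, only, none or still open, it means among the compounds named here.

- compound 1 `CN1CCC(C(=O)N2Cc3c(NC(=O)C4CC4)n[nH]c3C2(C)C)CC1`: > 225000 nM (a limit)
- compound 2 `CN1CCC(C(=O)N2Cc3c(NC(=O)c4cccs4)n[nH]c3C2(C)C)CC1`: 155000 nM
- compound 3 `CN1CCC(C(=O)N2Cc3c(NC(=O)c4ccc(F)c(F)c4)n[nH]c3C2(C)C)CC1`: > 225000 nM (a limit)

All three values come from a physicochemical assay for solubility, at pH 7; on this read-out higher numbers stand for higher solubility and lower numbers for lower solubility. Compound 3 has no number there, only a limit, > 225000 nM. That limit is the limit of > 225000 nM in this assay, at which 2 of the 3 values shown sit.

Compound 4 `CCCNC(=O)Nc1n[nH]c2c1CN(C(=O)C1CCN(C)CC1)C2(C)C` keeps the shared core and has propylamino in place of 3,4-difluorophenyl on a carbonyl carbon. For the measured compounds named here, no measured compound carries propylamino, so the nearest guides are the other exchanges at that carbonyl carbon. They give an at least 1.4-fold lower number from compound 1 to compound 2 (0.16 log units; that floor lies within the scatter) and an at least 1.4-fold higher number from compound 2 to compound 3 (0.16 log units; that floor lies within the scatter), and the third is a step that the two limits leave unreadable from compound 1 to compound 3. As far as these compounds go, the first two sizes are only floors, so their true sizes stay open. Going by the values given here, compound 2 is the only one with a number, 155000 nM.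

On this slim evidence, no change beyond the scatter is expected in either direction, and the assay may again report only a limit. The expected step is an at least 1.0-fold lower number from compound 3 to compound 4 (0.02 log units; that floor lies within the scatter). For compound 4 the estimate is 210000 nM, with an expected range of 110000 nM to 400000 nM.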

Compound 4, solubility: > 225000 nM
Compound 4 gave a limit, no number; the forecaster's own chance of this, stated with the estimate: 55%; middle value at least 1.0-fold (0.02 log units) from the limit.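

With propylamino, the carbonyl carbon carries a group with no ring for the first time among these compounds, and one with a hydrogen-bond donor, yet in this assay the read-out of compound 4 is again only a limit, as it was for compound 1 and compound 3. Against compound 2, the only compound with a number, the exchange of thiophen-2-yl for propylamino gives an at least 1.4-fold higher number from compound 2 to compound 4 (0.16 log units; that floor lies within the scatter), so this comparison shows no difference beyond the scatter. The steps from compound 1 and from compound 3 to compound 4 cannot be read, and the position now yields three results that cannot be ranked against one another: the limit of > 225000 nM in this assay, at which 3 of the 4 values shown sit.

As far as these compounds go, how far compound 1, compound 3 and compound 4 actually differ from one another at this carbonyl carbon stays open, as does whether any of them truly differs from compound 2. Also open, from the compounds shown here alone, is whether a longer chain in place of propylamino, or a carboxylic acid or tertiary amine at the end of that chain, would give a number in this assay rather than a limit.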